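The source may report more compounds than this note shows. Statements on the series, on what has been measured and on what is new or still open speak of the compounds shown alone.

Values measured in a physicochemical assay for lipophilicity; on this read-out lower numbers stand for lower lipophilicity and higher numbers for higher lipophilicity:
- compound 1 `C=C(c1ccc2ccccc2c1)C1CCC2(CC1)COC(Nc1ccc(C)cc1)OO2`: 6.08
- compound 2 `C=C(c1ccc2ccccc2c1)C1CCC2(CC1)COC(Nc1ccc(OC)cc1)OO2`: 5.46

Of these two compounds, compound 2 has the lower number, at 5.46. Compound 3 `C=C(c1ccc2ccccc2c1)C1CCC2(CC1)COC(Nc1cccc(C(F)(F)F)c1)OO2` has 3-(trifluoromethyl)phenyl in place of 4-methoxyphenyl on an amine nitrogen. Among the compounds with values here, only one measured step bears on this change, methoxy in place of methyl on an aromatic carbon: a number 0.62 log units lower from compound 1 to compound 2 (beyond the scatter). Within the data shown here, compound 3 loses that methoxy, so a rise of similar or somewhat larger size is expected in this assay, although no trifluoromethyl compound has been measured. The expected step is a number 0.84 log units higher from compound 2 to compound 3 (beyond the scatter). For compound 3 the estimated value is 6.3, with an expected range from 5.8 to 6.8.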

Compound 3, partition coefficient: 6.51
Compound 3: the middle estimate sits 0.21 log units below what was measured; low and high end bracket the measured number.
By their numbers in this assay, from the lowest: compound 2; then compound 1; then compound 3.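

In this assay, within the data shown here, the aryl group on this amine nitrogen can now carry the number past the 4-methylphenyl compound (a number 0.43 log units higher from compound 1 to compound 3 (beyond the scatter)), and the widest gap among the three is the one from the 4-methoxyphenyl compound (a number 1.05 log units higher from compound 2 to compound 3 (beyond the scatter)). Both steps swap the group and its place on the ring together, so the two effects cannot be separated. Nothing given here explains these steps.

As far as these compounds go, whether an amine or a carboxylic acid on this ring would bring the number below that of compound 2 stays open. So does where plain phenyl would fall among the three.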